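Trimming the amide from thiophene to methyl

The source may report more compounds than this note shows. Statements on the series, on what has been measured and on what is new or still open speak of the compounds shown alone.

Measured compounds: compound 1 `Cc1cccc(Cn2c(CN3CCN(C(=O)c4cccs4)CC3)nc3ccccc32)c1` 60.8%; compound 2 `CC(C)Cn1c(CN2CCN(C(=O)C3CC3)CC2)nc2ccccc21` 13.1%; compound 3 `O=C(C1CC1)N1CCN(Cc2nc3ccccc3n2Cc2ccc(Cl)cc2)CC1` 56.6%.

In an assay on isolated protein for inhibition of aldehyde dehydrogenase 1A1 (Homo sapiens), read by spectrophotometry, tested at 10 uM (on this read-out higher numbers stand for more inhibition at the one concentration tested (going by the name of the read-out) and lower numbers for less inhibition), compound 1 gives the highest of the three numbers; compound 3 sits within the scatter of it, while compound 2 lies far below. Among the compounds with values here, the only measured step, a number 43.5 percentage points higher from compound 2 to compound 3 (beyond the scatter), concerns the group on the saturated chain carbon bound to the aromatic nitrogen, not the carbonyl. Compound 4 `CC(=O)N1CCN(Cc2nc3ccccc3n2Cc2cccc(C)c2)CC1` differs from compound 1 as methyl in place of thiophen-2-yl on a carbonyl carbon. Within the data shown here, no measured step touches that carbonyl carbon; the values of compound 1 and compound 3 merely show that two different carbonyl substituents give numbers within the scatter. With a much smaller group entering, a moderate downward step is expected, a number 15.8 percentage points lower from compound 1 to compound 4 (beyond the scatter). Compound 4 is therefore estimated at 45%, between 25% and 65%.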

Compound 4, a percentage reported as inhibition, at one concentration (the size of the read-out at that concentration, not a potency): 70.3%
Beside the measured number, compound 4's estimate is 25.3 percentage points below it; the measured number lies above the stated range.
By their numbers in this assay, from the lowest: compound 2; then compounds 3, 1 and 4 (each within the scatter of the next, the first and the last beyond it).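

In this assay, the carbonyl carbon now has a measured step of its own (a number 9.5 percentage points higher from compound 1 to compound 4 (within the scatter)). Thiophen-2-yl, with its five-membered aromatic ring, gives way to methyl, a single carbon, with the change staying within the scatter. On the core of compound 1, then, the ring on this carbonyl carbon is not required to keep this level of inhibition at the one concentration tested. No evidence at hand accounts for this result.

From the compounds shown here alone, what a longer chain such as butyl, or an amine such as dimethylamino, would give on this carbonyl carbon remains open.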